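The source may hold more compounds than are shown below. What is called first, only, known or untested is meant among the compounds shown, and "the series" means these compounds.

Of the compounds shown here, three sharing a core have been tested in a functional assay on blood (Homo sapiens) for inhibition; a higher number here means a weaker inhibitor, a lower number a stronger inhibitor. Compound 1 `O=C(Nc1cccnc1)Oc1ccc(OCc2nc3ccccc3s2)cc1C1(c2ccccc2)CC2CCC1C2` gives 37 nM; 86 nM; 33 nM (3 entries), and its full record is the several entries of compound 1 in this assay, 37 nM; 86 nM; 33 nM (3 entries). Compound 2 `COC(=O)COc1ccc(OCc2ccc3ccccc3n2)cc1C1(c2ccccc2)CC2CCC1C2`, a methyl ester, gives 290 nM.

Compound 3 `O=C(O)COc1ccc(OCc2ccc3ccccc3n2)cc1C1(c2ccccc2)CC2CCC1C2`, the corresponding carboxylic acid, stands at > 3000 nM. That figure is a limit of the assay and not a number.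

Compound 4 `CCCCOc1ccc(OCc2ccc3ccccc3n2)cc1C1(c2ccccc2)CC2CCC1C2` has yet to be measured in this assay. Its structure departs from that of compound 3 as follows: propyl in place of carboxy on a saturated chain carbon bound to an oxygen on an aromatic ring. Compound 4 thus carries propyl where compound 3 carries carboxy, so the free carboxy group is gone.

For the measured compounds named here, one measured step bears on this change: an at least 10-fold higher number from compound 2 to compound 3 (1.01 log units; beyond the scatter), a large step beyond the scatter, with hydrogen in place of methyl on an oxygen next to a carbonyl group. That step created the free carboxy group, whereas the present change removes it, so a step of similar size in the opposite direction is expected. The estimate means an at least 10-fold lower number from compound 3 to compound 4 (1.00 log units; beyond the scatter), an expected move to a lower number and a stronger inhibitor. The expected value for compound 4 is 300 nM, with an estimated range from 80 nM to 1300 nM.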

Compound 4, half-maximal inhibitory concentration: > 3000 nM
Compound 4: a limit, no number; the forecaster's own chance of this, stated with the estimate: 10%; middle value at least 10-fold (1.00 log units) away from the limit.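

In this assay compound 4 gives > 3000 nM, a limit of the assay and not a number, so swapping carboxymethoxy for butoxy at this position did not yield a measurable value, even though compound 4 has no free carboxy group. Against the methyl ester, the result is an at least 10-fold higher number from compound 2 to compound 4 (1.01 log units; beyond the scatter), so a large rise in the number at this position is now seen both with the free carboxy group and with a plain butyl chain, and the carboxy group alone cannot account for the loss seen in the acid. The step between the acid and the butyl compound cannot be read, and the two compounds can only be placed together at the same limit: the limit of > 3000 nM in this assay, at which 2 of the 4 values shown sit.

From the compounds shown here alone, how far compound 3 and compound 4 each lie past that limit stays open, and so does whether they differ at all. Also open, going by these compounds, is what a shorter chain, an amine or an amide at this position would give, and whether any group there can match or better the methyl ester.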